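The source may hold more compounds than are shown below. What is called first, only, known or untested is meant among the compounds shown, and "the series" means these compounds.

Compound 1 `CC(C)CC1n2cncc2CN(Cc2ccccc2)S1(=O)=O`, 14% in an assay on isolated protein for inhibition of Aromatase (Homo sapiens), tested at 1 uM; a lower number here means less inhibition, a higher number more inhibition at the concentration tested (going by the name of the read-out); compound 2 `C[C@@H](c1ccc(Cl)cc1)N1Cc2cncn2C(C[C@@H](O)c2ccccc2)S1(=O)=O`, 6%.

Compound 2 has the lower of the two numbers, but its gap to compound 1 lies within the scatter, so the two read as alike. Compound 3 `CC(C)CC1n2cncc2CN([C@@H](C)c2ccc(Cl)cc2)S1(=O)=O` has not been measured. The change from compound 2 to compound 3 is isopropyl in place of hydroxy(phenyl)methyl on a saturated chain carbon bound to a saturated ring carbon. Among the measured compounds shown here, with both measured compounds showing little inhibition and no step between them beyond the scatter, no move beyond the scatter is expected in this assay. Compound 3 is expected to give 10%, between 0% and 25%, a step of a number 4 percentage points higher from compound 2 to compound 3 (within the scatter) that is estimated to stay within the scatter.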

Compound 3, a percentage reported as inhibition, at one concentration (the size of the read-out at that concentration, not a potency): 56%
Compound 3: middle estimate off by 46 percentage points, on the low side; measured number above the stated range.
By their numbers in this assay, from the lowest: compounds 2 and 1 (each within the scatter of the next); then compound 3.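

In this assay, the place on a saturated chain carbon bound to a saturated ring carbon proves far from silent: isopropyl in place of hydroxy(phenyl)methyl gives a number 50 percentage points higher from compound 2 to compound 3 (beyond the scatter), a move the earlier pair, alike within the scatter, gave no sign of. The change removes an aromatic ring, a hydrogen-bond donor and a hydrogen-bond acceptor together, so the compounds cannot assign the step to any one of them. Nothing measured here explains the step. Still open, going by these compounds, is how a smaller methyl, a longer chain or an amine would read at this place. Also open, on these data alone, is whether a plain 2-phenylethyl, without the hydroxy, would read like compound 2 or compound 3.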